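Swapping one fused amine for its isomer in metabolic stability

The source may hold more compounds than are shown below. What is called first, only, known or untested is meant among the compounds shown, and "the series" means these compounds.

Measured compounds:
- Compound 1 `CN1CCN(Nc2cccc3c2C[C@@H](CN(C)[C@H]2CCCc4cccnc42)NC3)CC1` — 73.6%
- Compound 2 `CN1CC[C@H]2CN(c3cccc4c3C[C@H](CN(C)[C@H]3CCCc5cccnc53)NC4)C[C@H]21` — 87.3%
- Compound 3 `CN(C[C@H]1Cc2c(cccc2N[C@H]2CC[C@H](N)CC2)CN1)[C@H]1CCCc2cccnc21` — 100%

In an ADME assay on microsomes from liver (Homo sapiens) for metabolic stability, using NADPH, with a stated time of 10 min (a lower number here means that less of the compound is left, a higher number that more of the compound is left), compound 2 gives 87.3%. Among the three measured compounds, compound 2 stands second highest: compound 3 lies above it, and compound 1 lies below it, both beyond the scatter.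

Compound 4 `CN1C[C@@H]2CN(c3cccc4c3C[C@H](CN(C)[C@H]3CCCc5cccnc53)NC4)C[C@@H]2C1` has not yet been measured. It differs from compound 2 only in the group on the aromatic carbon: a group of 9 heavy atoms (7 carbon, 2 nitrogen; 2 five-membered non-aromatic rings with 1 hetero atom each) in place of a group of 9 heavy atoms (7 carbon, 2 nitrogen; 2 five-membered non-aromatic rings with 1 hetero atom each), on an aromatic carbon. The group that leaves and the group that enters have the same atoms, joined differently.

For the measured compounds named here, only one measured step touches the same position. From compound 2 to compound 3, where the leaving group is exchanged for a smaller one, the change was a number 12.7 percentage points higher from compound 2 to compound 3 (beyond the scatter). Going by the values given here, no measured step exchanges the group for an isomer of itself, so that step gives only a loose guide. Since the atoms are unchanged, a step of a number 0.3 percentage points lower from compound 2 to compound 4 (within the scatter) is expected, that is none beyond the scatter. Compound 4 is therefore estimated at 87%, with a range from 72% to 100%.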

Compound 4, percent of the compound remaining: 100%
Compound 4: middle estimate off by 13 percentage points, on the low side, and the stated range covers the measured number.
By their numbers in this assay, from the lowest: compound 1; then compound 2; then compounds 3 and 4 (each within the scatter of the next).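

At this aromatic carbon, the count of atoms and rings does not settle the outcome: in this assay, rejoining the same atoms gives a number 12.7 percentage points higher from compound 2 to compound 4 (beyond the scatter), so an exchange of isomers alone can move the read-out beyond the scatter. The larger group also need not give way to a smaller one to reach this level, as the exchange between the group of 8 heavy atoms and the group of 9 shows no change at the digits printed from compound 3 to compound 4 (within the scatter). No measurement at hand explains why the two isomers differ.

For the compounds shown here, the single step from compound 2 to compound 4 cannot separate the effect of how the rings are joined from that of the defined stereocentres. On these data alone, whether a morpholine or an open-chain diamine on the same aromatic carbon would match compound 2 or compound 4 remains open.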